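The source may hold more compounds than are shown below. What is called first, only, known or untested is meant among the compounds shown, and "the series" means these compounds.

Compound 1 `COc1nc2ccc(Br)cc2cc1C(c1ccccc1)n1cc(-c2ccc(Br)cc2)nn1` was tested in an ADME assay on HEK293 cells (Homo sapiens) for cytotoxicity, read by sulforhodamine B assay, with a stated time of 48 h, tested at 10 uM (on this read-out lower numbers stand for less inhibition and higher numbers for more inhibition at the one concentration tested (going by the name of the read-out)), where compound 1 gives 6.28%. Two close relatives were measured alongside it: compound 2 `COc1nc2ccc(Br)cc2cc1C(c1ccccc1)n1cc(-c2ccccc2)nn1` gives 8.25% and compound 3 `COc1nc2ccc(Br)cc2cc1C(c1ccccc1)n1cc(-c2ccccc2F)nn1` gives 3.97%. Among these three numbers compound 1 stands second highest, but its step to either neighbour is small: a number 2 percentage points higher from compound 1 to compound 2 (within the scatter), and a number 2.3 percentage points lower from compound 1 to compound 3 (within the scatter). The step between the other two is likewise small, a number 4.3 percentage points lower from compound 2 to compound 3 (within the scatter), so none of the three compounds can be told apart on this read-out.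

The unmeasured compound 4 `COc1nc2ccc(Br)cc2cc1C(c1ccccc1)n1cc(-c2cccc(F)c2)nn1` differs from compound 1 in one place: 3-fluorophenyl in place of 4-bromophenyl on an aromatic carbon. Within the data shown here, the change most like it is the one from compound 1 to compound 3, which also swaps the 4-bromophenyl for a fluorine-bearing phenyl, and that step stayed inside the scatter. Removing the bromine alone, from compound 1 to compound 2, also stayed inside the scatter. Compound 4 is therefore expected to give 5.5%, with a likely range from 0% to 12%. The expected step is a number 0.8 percentage points lower from compound 1 to compound 4 (within the scatter), which means no change beyond the scatter.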

Compound 4, a percentage reported as inhibition, at one concentration (the size of the read-out at that concentration, not a potency): 6.84%
For compound 4 the middle estimate is 1.3 percentage points below the measured one; the measured number falls inside the stated range.
By their numbers in this assay, from the lowest: compounds 3, 1, 4 and 2 (each within the scatter of the next).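

Swapping 2-fluorophenyl for 3-fluorophenyl in this assay gives a number 2.9 percentage points higher from compound 3 to compound 4 (within the scatter), so this pair shows no readable effect of where the fluoro sits on the phenyl ring. The other two steps agree: 3-fluorophenyl in place of 4-bromophenyl gives a number 0.6 percentage points higher from compound 1 to compound 4 (within the scatter), and fluoro in place of hydrogen gives a number 1.4 percentage points lower from compound 2 to compound 4 (within the scatter), so these changes on the phenyl ring borne by the five-membered aromatic ring with 3 nitrogen leave the read-out within the scatter. No supporting measurement is available to explain these results.

Going by these compounds, only hydrogen, fluoro and bromo appear on this phenyl ring, so the effect of an amine or a carboxylic acid there, or of a longer alkyl chain replacing the ring, remains open. On these data alone, each compound has a reading at just one concentration, so behaviour at other concentrations also remains open.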